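This account rests on a few compounds, and the source may have more. Where it says the series, first, only, none or still open, it means among the compounds named here.

Three compounds have been measured in an assay on HEK293 cells for displacement of a labelled ligand from 5-hydroxytryptamine receptor 6 (Homo sapiens); on this read-out lower numbers stand for stronger inhibition and higher numbers for weaker inhibition:

Compound 1, `O=C1c2ccccc2S(=O)(=O)N1CCCCCCN1CCN(c2cccc(Cl)c2Cl)CC1`: 72 nM
Compound 2, `O=C1c2ccccc2S(=O)(=O)N1CCCCCCN1CCN(c2ncccn2)CC1`: 5710 nM
Compound 3, `COc1ccccc1N1CCN(CCCCCN2C(=O)c3ccccc3S2(=O)=O)CC1`: 1990 nM

Compound 2 gives the highest number of the three in this assay; compound 3 comes nearest to it, and compound 1 lies furthest away, so compound 2 is the weakest binder among the measured set. Compound 4, `COc1ccccc1N1CCN(CCCCCCN2C(=O)c3ccccc3S2(=O)=O)CC1`, differs from compound 2 in one place: 2-methoxyphenyl in place of pyrimidin-2-yl on an amine nitrogen in a ring.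

Among the measured compounds shown here, one measured step bears directly on this change. Going the other way, from an aryl group to the pyrimidinyl group, gave a 79-fold higher number from compound 1 to compound 2 (1.90 log units; beyond the scatter). Restoring an aryl group on that ring nitrogen should therefore move the number back down, though the two aryl groups are not the same. Compound 3, which carries the same 2-methoxyphenyl group on a shorter chain, gives 1990 nM, a lower number than compound 2 shows, which points the same way. The chain length itself is not paired anywhere in the measured set.

Compound 4 is expected to show a clearly lower number than compound 2, a step of about a 5.7-fold lower number from compound 2 to compound 4 (0.76 log units; beyond the scatter). Compound 4 is estimated at 1000 nM, with a range from 300 nM to 4000 nM.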

Compound 4, inhibition constant: 779 nM
For compound 4 the middle estimate is 1.3-fold (0.11 log units) above the measured one; the measured number falls inside the stated range.
By their numbers in this assay, from the lowest: compound 1; then compound 4; then compound 3; then compound 2.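

In this assay, on the shared core with the same chain, replacing pyrimidin-2-yl with 2-methoxyphenyl on the amine nitrogen in the ring gives a 7.3-fold lower number from compound 2 to compound 4 (0.87 log units; beyond the scatter), so the gain seen with 2,3-dichlorophenyl is not confined to that one group. The position also separates the two groups with a six-membered aromatic ring of carbon only: replacing 2,3-dichlorophenyl with 2-methoxyphenyl gives an 11-fold higher number from compound 1 to compound 4 (1.03 log units; beyond the scatter), so on this chain the numbers run from 2,3-dichlorophenyl, through 2-methoxyphenyl, to pyrimidin-2-yl. No measurement shown here accounts for this order in terms of any property of the groups.

Going by these compounds, the two 2-methoxyphenyl compounds hint at a role for the chain, with compound 3 at 1990 nM on the shorter chain and compound 4 at 779 nM, but it remains open whether the order of the groups on the ring nitrogen would hold on the shorter chain or on a heptyl chain. Also open, on these data alone, is where an unsubstituted phenyl, a 3-chlorophenyl or a pyridin-2-yl group would fall in this order.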